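From compound 2 to compound 3: changing the amide chain

A few compounds are considered here, and "the series" means these few. Any claim that something is new, unique, unknown or untested is made for them only; others in the source may bear on it.

Measured in a functional assay on MCF7 cells (Homo sapiens) for antiproliferative activity, read by MTT assay, with a stated time of 72 h; a higher number here means a weaker inhibitor, a lower number a stronger inhibitor:
Compound 1 `CCn1cc(C(CC)(CC)c2ccc(C#CC(O)(CC)CC)c(C)c2)cc1C(=O)NCCCN(C)C`: 20200 nM
Compound 2 `CCn1cc(C(CC)(CC)c2ccc(C#CC(O)(CC)CC)c(C)c2)cc1C(=O)NCCC(=O)O`: 30600 nM

For the measured compounds named here, only these two numbers are known so far, and compound 2 cannot be told apart from compound 1, its only neighbour. The measured step is a 1.5-fold higher number from compound 1 to compound 2 (0.18 log units; within the scatter). It put carboxy in place of (dimethylamino)methyl on a saturated chain carbon, two bonds along the chain from an amide-type nitrogen.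

Compound 3 `CCn1cc(C(CC)(CC)c2ccc(C#CC(O)(CC)CC)c(C)c2)cc1C(=O)N[C@H](C(=O)O)C(C)C` keeps the shared core and changes the group on that amide-type nitrogen: 1-carboxy-2-methylpropyl in place of 2-carboxyethyl on an amide-type nitrogen. In words, 1-carboxy-2-methylpropyl stands in place of 2-carboxyethyl, and the new group brings a defined stereocentre.

Going by the values given here, the single measured step is the only guide, and it is a thin one, since it involved a different change. No data yet show what this new group does, so a large move cannot be ruled out. The estimated step is a 1.0-fold lower number from compound 2 to compound 3 (0.01 log units; within the scatter), which means none beyond the scatter is expected in this assay. Compound 3 is expected at about 30000 nM, within an estimated range of 12000 nM to 75000 nM.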

Compound 3, half-maximal inhibitory concentration: 12600 nM
Compound 3: the middle estimate sits 2.4-fold (0.38 log units) above what was measured, and the stated range covers the measured number.
By their numbers in this assay, from the lowest: compounds 3, 1 and 2 (each within the scatter of the next, the first and the last beyond it).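

In this assay the group on the amide-type nitrogen can move the number beyond the scatter, which the earlier step did not show: the change to 1-carboxy-2-methylpropyl gives a 2.4-fold lower number from compound 2 to compound 3 (0.39 log units; beyond the scatter) as a modest step, even though a carboxy group is present in both the old and the new group. The size of this effect depends on the comparison, since replacing 3-(dimethylamino)propyl with the same group gives a 1.6-fold lower number from compound 1 to compound 3 (0.20 log units; within the scatter) and so leaves compound 1 and compound 3 indistinguishable in this assay. No measurement available here explains the step from compound 2 to compound 3.

The new group differs from 2-carboxyethyl in its heavy atoms and also brings a defined stereocentre, and the compounds shown do not separate these two differences. A plain carboxymethyl group, a 1-carboxyethyl group or the mirror-image form of 1-carboxy-2-methylpropyl on the same nitrogen would each test a separate part of the change, and an amine in place of the carboxy group on the new chain would test whether the carboxy group matters there.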